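Cyclobutyl to isobutyl on the sulfonyl sulfur

A few compounds are considered here, and "the series" means these few. Any claim that something is new, unique, unknown or untested is made for them only; others in the source may bear on it.

For the measured compounds named here, compound 1 `O=C([C@@H]1CCCN(S(=O)(=O)c2ccc(S(=O)(=O)C3CCC3)cc2)C1)N1CCC(F)(F)CC1` gives the lowest number of the three measured so far in a functional assay on MIA PaCa-2 cells (Homo sapiens) for inhibition, read by MTT assay, with a stated time of 7 days (a higher number here means a weaker inhibitor, a lower number a stronger inhibitor), at 9 nM. Compound 2 `CCN(CC)S(=O)(=O)c1ccc(S(=O)(=O)N2CCC[C@@H](C(=O)N3CCS(=O)(=O)CC3)C2)cc1` gives 900 nM, and compound 3 `CCN(CC)S(=O)(=O)c1ccc(S(=O)(=O)N2CCC[C@@H](C(=O)N[C@H]3CC[C@H](OC)CC3)C2)cc1` gives 1350 nM, both gaps to compound 1 lying beyond the scatter. Both of these compounds differ from compound 1 at the sulfonyl sulfur and on the carbonyl carbon at once, so neither gap isolates a single change. Going by the values given here, the one single-point step in the set, a 1.5-fold higher number from compound 2 to compound 3 (0.18 log units; within the scatter), concerns the carbonyl side only and says nothing about the substituent on the sulfonyl sulfur.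

Compound 4 `CC(C)CS(=O)(=O)c1ccc(S(=O)(=O)N2CCC[C@@H](C(=O)N3CCC(F)(F)CC3)C2)cc1` differs from compound 1 in one place: isobutyl in place of cyclobutyl on a sulfonyl sulfur. Among the compounds with values here, no measured step bears directly on this change; the only guidance is that the single-point step already seen stayed within the scatter. The expected step in this assay is therefore small, a 1.7-fold higher number from compound 1 to compound 4 (0.22 log units; within the scatter), without clear direction. The estimate for compound 4 is 15 nM, within a range of 5 nM to 45 nM.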

Compound 4, half-maximal inhibitory concentration: 80 nM
Compound 4: the middle estimate sits 5.3-fold (0.73 log units) below what was measured, outside the stated range (above it).
By their numbers in this assay, from the lowest: compound 1; then compound 4; then compounds 2 and 3 (each within the scatter of the next).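

The substituent on the sulfonyl sulfur is not a silent position in this assay: replacing cyclobutyl with isobutyl leaves the heavy-atom count unchanged, yet gives an 8.9-fold higher number from compound 1 to compound 4 (0.95 log units; beyond the scatter). For the compounds shown here, this is the first single-point reading at this position, and unlike a 1.5-fold higher number from compound 2 to compound 3 (0.18 log units; within the scatter) on the carbonyl side, it lies beyond the scatter. Nothing available explains why the open isobutyl group gives the higher number.

As far as these compounds go, whether the ring itself or only the shape of this particular chain sets the gap remains open; cyclopropyl, cyclopentyl and n-butyl on the same sulfonyl sulfur would help separate these readings. From the compounds shown here alone, the step is also known only with the carbonyl side of compound 1, so its size with other groups on that carbonyl carbon remains unknown.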